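The compounds below may be only part of what the source reports. "The series", "measured", "known", "first", "only" and "open" are said of these compounds alone.

Compound 1, `COc1cccc(OC(=O)c2cc(O)c(O)c(O)c2)c1OC(=O)c1cc(O)c(O)c(O)c1`, and compound 2, `O=C(Oc1cccc(F)c1OC(=O)c1cc(O)c(O)c(O)c1)c1cc(O)c(O)c(O)c1`, share one core; compound 2 carries fluoro in place of methoxy on an aromatic carbon. In a functional assay on NCI-H1299 cells (Homo sapiens) for inhibition, read by scintillation counting, with a stated time of 30 min, tested at 30 uM (on this read-out lower numbers stand for less inhibition and higher numbers for more inhibition at the one concentration tested (going by the name of the read-out)), compound 1 gives 58.4%, while compound 2 gives 81.1%, so that the step is a number 22.7 percentage points higher from compound 1 to compound 2 (beyond the scatter). Compound 3, `COc1cccc(OC(=O)c2ccccc2O)c1OC(=O)c1ccccc1O`, rests on a different core, and the difference between the two cores is not broken down here. In this assay compound 3 gives 50.5%. Compound 4, `O=C(Oc1cccc(F)c1OC(=O)c1ccccc1O)c1ccccc1O`, is not yet measured; it differs from compound 3 by fluoro in place of methoxy on an aromatic carbon, the same change as between compound 1 and compound 2. Among the compounds with values here, on the one example of compound 1 to compound 2, a step of a number 19.5 percentage points higher from compound 3 to compound 4 (beyond the scatter) is expected from compound 3 to compound 4 because the same change produced a number 22.7 percentage points higher from compound 1 to compound 2 (beyond the scatter). Compound 4 is therefore estimated at 70%, within 50% to 88%.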

Compound 4, a percentage reported as inhibition, at one concentration (the size of the read-out at that concentration, not a potency): 51%
Beside the measured number, compound 4's estimate is 19 percentage points above it, within the range that was stated.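

In this assay, fluoro in place of methoxy gives a number 0.5 percentage points higher from compound 3 to compound 4 (within the scatter), so the gain seen with this change on the core of compound 1 does not appear on the second core. Within the data shown here, the two results differ, so one result cannot be carried over to the other core: the same change on two cores in this assay, a number 22.7 percentage points higher (beyond the scatter) from compound 1 to compound 2 and a number 0.5 percentage points higher (within the scatter) from compound 3 to compound 4, 22.2 percentage points apart, beyond the scatter of two such steps With only two pairs, this shows that the size of the step can depend on the core, but it does not show which difference between the cores matters or what the change would do on a further core.

The compounds shown carry only methoxy or fluoro at this place on the ring, so the outcome with an amine, a chloro group or a longer chain such as ethoxy remains open. Also open, on these data alone, is whether a further core would follow the first pair, the second pair or neither.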